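The source may hold more compounds than are shown below. What is called first, only, known or untested is meant among the compounds shown, and "the series" means these compounds.

Measured in a functional assay on KB-V1 cells (Homo sapiens) for cytotoxicity, read by MTT assay, with a stated time of 72 h; on this read-out higher numbers stand for weaker inhibition and lower numbers for stronger inhibition:
Compound 1 `O=C1Nc2ccccc2/C1=N/NC(=S)NCc1ccccc1`: 7630 nM
Compound 2 `O=C1Nc2ccccc2/C1=N/NC(=S)NC1CCCCC1`: 4380 nM
Compound 3 `CC(C)NC(=S)N/N=C1\C(=O)Nc2ccccc21`: 10300 nM

These three share one core and differ only in the group on an amide-type nitrogen. Compound 3, which carries isopropyl there, can be separated from only one of the other two. The data show a 2.4-fold higher number from compound 2 to compound 3 (0.37 log units; beyond the scatter), whereas a 1.3-fold higher number from compound 1 to compound 3 (0.13 log units; within the scatter) leaves it level with the benzyl compound.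

Compound 4 `CNC(=S)N/N=C1\C(=O)Nc2ccccc21` has not yet been measured. It carries methyl in place of isopropyl on an amide-type nitrogen. Within the data shown here, no measured compound has methyl at this nitrogen, so the guidance is indirect. Among the measured compounds shown here, the closest precedent is the swap of cyclohexyl for isopropyl, which also removes carbon from this group and gave a 2.4-fold higher number from compound 2 to compound 3 (0.37 log units; beyond the scatter). The other changes at this nitrogen were smaller, with a 1.7-fold lower number from compound 1 to compound 2 (0.24 log units; within the scatter) for cyclohexyl in place of benzyl. None of the three steps is large, so a slight rise in the number is expected, with no sharp jump. The expected step is a 1.5-fold higher number from compound 3 to compound 4 (0.16 log units; within the scatter). Compound 4 is expected at 15000 nM, with an estimated range from 7000 nM to 30000 nM.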

Compound 4, half-maximal inhibitory concentration: 19400 nM
For compound 4 the middle estimate is 1.3-fold (0.11 log units) below the measured one, and the stated range covers the measured number.
By their numbers in this assay, from the lowest: compounds 2, 1, 3 and 4 (each within the scatter of the next, the first and the last beyond it).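

In this assay, methyl is the only group shown at this nitrogen that separates from both ring-bearing groups, with a 4.4-fold higher number from compound 2 to compound 4 (0.65 log units; beyond the scatter) and a 2.5-fold higher number from compound 1 to compound 4 (0.41 log units; beyond the scatter), whereas isopropyl separated only from cyclohexyl. Yet methyl and isopropyl themselves stay level, with a 1.9-fold higher number from compound 3 to compound 4 (0.27 log units; within the scatter), so compound 3 cannot be told apart from compound 1 or compound 4 even though those two lie apart; shortening the group shows a clear effect only when the comparison spans the whole set, not in this last step alone. Nothing available here accounts for these differences.

The compounds shown do not tell whether the lower numbers of compound 1 and compound 2 go with the ring or simply with the larger number of carbons, since each ring-bearing group here also has more carbons than isopropyl or methyl. An open chain such as n-hexyl would bear on that question, and a phenyl placed directly on the nitrogen, or a chain ending in an amine, would show how far this position tolerates other kinds of group.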